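Five-membered ring swap: 1,2-oxazol-4-yl for 2-methyl-1,3-oxazol-4-yl

The compounds below may be only part of what the source reports. "The series", "measured", "known", "first", "only" and "open" are said of these compounds alone.

Measured so far:
compound 1 `Cc1nc(-c2ccccc2NCC2=NCCN2)cs1`: 69.2 nM
compound 2 `Cc1nc(-c2ccccc2NCC2=NCCN2)co1`: < 5020 nM (a limit)

In a functional assay for activation of Alpha-1B adrenergic receptor (Homo sapiens), read by calcium flux (a higher number here means that more compound is needed for the effect, a lower number that less compound is needed), compound 1 gives 69.2 nM. For compound 2 only a limit is known in this assay, < 5020 nM (the limit of < 5020 nM in this assay, at which 1 of the 2 values shown sits). The step that the limit leaves unreadable from compound 1 to compound 2 is thus of unreadable size. Compound 3 `c1ccc(-c2cnoc2)c(NCC2=NCCN2)c1` differs from compound 2 by 1,2-oxazol-4-yl in place of 2-methyl-1,3-oxazol-4-yl on an aromatic carbon. Among the measured compounds shown here, no measured step covers this change; the one measured step is unreadable, so the expectation rests on compound 2 standing at a limit. Compound 3 is expected near 2000 nM, in the range 300 nM to 10000 nM, with an expected step that the limit leaves unreadable from compound 2 to compound 3 carrying wide uncertainty.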

Compound 3, half-maximal effective concentration: < 100000 nM
Compound 3 was reported as a limit (the forecaster's own chance of this, stated with the estimate: 35%); the middle value is on the limit's open side.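

In this assay, among the compounds shown here, compound 3 gives only a limit, < 100000 nM, so no step from compound 1 or compound 2 to it can be read. The compounds shown leave open how 1,2-oxazol-4-yl compares with 2-methyl-1,3-oxazol-4-yl or 2-methyl-1,3-thiazol-4-yl on the shared core.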